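A few compounds are considered here, and "the series" means these few. Any claim that something is new, unique, unknown or untested is made for them only; others in the source may bear on it.

Compound 1 `O=C1Nc2ccccc2CN1C[C@H]1CC[C@H](C(=O)N2CCN(c3ccccc3)CC2)CC1`: 5700 nM
Compound 2 `O=C1c2ccccc2C(=O)N1C[C@H]1CC[C@H](C(=O)N2CCN(c3ccccc3)CC2)CC1`: > 30000 nM (a limit)
Compound 3 `O=C1CCNC(=O)N1C[C@H]1CC[C@H](C(=O)N2CCN(c3ccccc3)CC2)CC1`: > 30000 nM (a limit)

In a functional assay on DBTRG cells (Homo sapiens) for inhibition, read by a luciferase reporter, with a stated time of 24 h (on this read-out higher numbers stand for weaker inhibition and lower numbers for stronger inhibition), compound 3 gives > 30000 nM, which is a limit of the assay and not a number. This is the limit of > 30000 nM in this assay, at which 2 of the 3 values shown sit. Only compound 1 gives a number, 5700 nM.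

Compound 4 `CC(C)C1CC(=O)N(C[C@H]2CC[C@H](C(=O)N3CCN(c4ccccc4)CC3)CC2)C(=O)N1` departs from compound 3 in a single place, with isopropyl in place of hydrogen on a saturated ring carbon. No measured pair among these compounds shows what such a change does, so any expectation is a loose one. A modest move towards stronger inhibition is expected, although compound 4 may well stay at the limit. Compound 1, at 5700 nM, gives the only numerical reference for how far that move might go. The estimate corresponds to an expected at least 1.6-fold lower number from compound 3 to compound 4 (0.22 log units; that floor lies within the scatter). Compound 4 is estimated at 18000 nM, with an expected range from 6000 nM to 30000 nM.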

Compound 4, half-maximal inhibitory concentration in the DBTRG assay: > 30000 nM
Compound 4: no number, only a limit (the forecaster's own chance of this, stated with the estimate: 55%); middle value at least 1.6-fold (0.22 log units) away from the limit.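

In the DBTRG assay compound 3 gives > 30000 nM, which is a limit of the assay and not a number. In the DBTRG assay compound 4 gives > 30000 nM, which is also a limit of the assay and not a number. In the DBTRG assay no step can be read from compound 3 to compound 4, because both compounds stand at the same limit of the assay: the limit of > 30000 nM in the DBTRG assay, at which 3 of the 4 values shown sit.

The compounds shown leave open whether isopropyl in place of hydrogen on a saturated ring carbon changes inhibition at all.

In a physicochemical assay for solubility, at pH 7.4 (on this read-out lower numbers stand for lower solubility and higher numbers for higher solubility), compound 3 gives 242000 nM and compound 4 gives 168000 nM, two values within the scatter of each other.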